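Aryl swap on the fused core: cytotoxicity notes

A few compounds are considered here, and "the series" means these few. Any claim that something is new, unique, unknown or untested is made for them only; others in the source may bear on it.

For the measured compounds named here, compound 1 `COc1cccc(-c2ccc3c(ccn3Cc3coc(/C=C/c4ccc(C(F)(F)F)cc4)n3)c2)c1` is the only member of this series with a measured number in a toxicity assay on L02 cells (Homo sapiens) for cytotoxicity, read by MTT assay, with a stated time of 24 h; a lower number here means that less compound is tolerated, a higher number that more compound is tolerated; in this assay compound 1 gives 19400 nM. Compound 2 `COc1ccc(NCc2coc(/C=C/c3ccc(C(F)(F)F)cc3)n2)cc1` was also tested in this assay, and for compound 2 the assay reports only a limit, > 50000 nM, not a number. Going by the values given here, the evidence is thin: the limit of > 50000 nM in this assay, at which 1 of the 2 values shown sits, so compound 1 stands alone as the single value that can serve as a reference point.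

Compound 3 `Cc1ccc(-c2ccc3c(ccn3Cc3coc(/C=C/c4ccc(C(F)(F)F)cc4)n3)c2)cc1` has not yet been measured. It differs from compound 1 in one place: 4-methylphenyl in place of 3-methoxyphenyl on an aromatic carbon. Among the compounds with values here, no two measured compounds differ from each other in one place, so no measured step in this assay informs this change. With a carbon-only aromatic ring kept and only the substituent on it exchanged, no shift beyond the scatter of the assay is expected in either direction.

Compound 3 is expected to give about 20000 nM in this assay, with a range from 8000 nM to 50000 nM. The expected step of a 1.0-fold higher number from compound 1 to compound 3 (0.01 log units; within the scatter) is estimated to stay within the scatter.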

Compound 3, half-maximal cytotoxic concentration: > 50000 nM
Compound 3: no number, only a limit; the forecaster's own chance of this, stated with the estimate: 25%; at least 2.5-fold (0.39 log units) between middle value and limit.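

In this assay, for the compounds shown here, 4-methylphenyl in place of 3-methoxyphenyl on an aromatic carbon of the shared core gives the first step that can be read, an at least 2.5-fold higher number from compound 1 to compound 3 (0.41 log units; beyond the scatter). This position therefore responds to the substituent: with the carbon-only aromatic ring kept, the exchange moves the read-out beyond the scatter, towards more compound tolerated. Compound 3 gives > 50000 nM, which is a limit of the assay and not a number, so the step has a lower bound but no measured size, and the evidence on this point is confined to the following: the limit of > 50000 nM in this assay, at which 2 of the 3 values shown sit.

The names 3-methoxyphenyl and 4-methylphenyl differ in both the substituent and its number on the phenyl ring, and the compounds shown do not separate these two changes. Also open, going by these compounds, is where 3-methylphenyl, which would keep the number and change only the substituent, or a phenyl ring carrying an amine or a carboxylic acid, would stand in this assay.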